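Trimethoxyphenyl in place of dimethoxyphenyl on the shared core

A few compounds are considered here, and "the series" means these few. Any claim that something is new, unique, unknown or untested is made for them only; others in the source may bear on it.

Of the compounds shown here, two have been measured in an ADME assay on HEK293 cells (Homo sapiens) for antiproliferative activity, read by MTT assay, with a stated time of 24 h; on this read-out lower numbers stand for stronger inhibition and higher numbers for weaker inhibition. Compound 1 `COc1ccc(C(=O)/C=C/c2cc(-c3cc(OC)c(OC)c(OC)c3)n3nc(-c4ccccc4)cc3n2)cc1` gives 79800 nM, while compound 2 `COc1ccc(C(=O)/C=C/c2cc(-c3ccc(OC)c(OC)c3)n3nc(-c4ccccc4)cc3n2)cc1OC` gives 32500 nM, the lowest of the two numbers and the only point of reference for the next step. Compound 3 `COc1ccc(C(=O)/C=C/c2cc(-c3cc(OC)c(OC)c(OC)c3)n3nc(-c4ccccc4)cc3n2)cc1OC` differs from compound 2 by methoxy in place of hydrogen on an aromatic carbon. Going by the values given here, no measured pair isolates this change, so the expected step is uncertain; a modest rise in this assay, near the edge of the scatter, seems most likely. Compound 3 is expected at 45000 nM, within 18000 nM to 110000 nM, so that a 1.4-fold higher number from compound 2 to compound 3 (0.14 log units; within the scatter) is the estimated step.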

Compound 3, half-maximal inhibitory concentration: 81700 nM
For compound 3 the middle estimate is 1.8-fold (0.26 log units) below the measured one; the measured number falls inside the stated range.
By their numbers in this assay, from the lowest: compound 2; then compounds 1 and 3 (each within the scatter of the next).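

Going by these compounds alone, replacing 3,4-dimethoxyphenyl with 3,4,5-trimethoxyphenyl gives a 2.5-fold higher number from compound 2 to compound 3 (0.40 log units; beyond the scatter) in this assay, the first reading of this change at this position. Methoxy in place of hydrogen on an aromatic carbon elsewhere in the molecule gives a 1.0-fold higher number from compound 1 to compound 3 (0.01 log units; within the scatter), so among these compounds the exchange registers beyond the scatter only at the first position. No available evidence accounts for this difference. Only hydrogen and methoxy are seen at this position. From the compounds shown here alone, whether a hydroxyl group, fluorine or an amine there would give a similar number remains open.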